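This account rests on a few compounds, and the source may have more. Where it says the series, first, only, none or still open, it means among the compounds named here.

Compound 1, `CCCSc1nc(N)nc2c1ncn2/C=C1/CC1(CO)CO`, in an ADME assay on BCBL1 cells (Homo sapiens) for cytotoxicity, with a stated time of 7 days; a higher number here means that more compound is tolerated, a lower number that less compound is tolerated: > 20000 nM, a limit of the assay.
Compound 2, `Nc1nc2c(ncn2/C=C2/CC2(CO)CO)c(=O)[nH]1`, in this assay: > 20000 nM, also a limit of the assay.

Compound 1 carries a propylsulfanyl group on the shared core, while compound 2 carries a carbonyl and ring nitrogen hydrogen in its place. Within the data shown here, neither compound gives a number in this assay: for compound 1 only a limit is known, and the one further value shown is a limit too, so there is no measured step between them to speak of. Both values sit at the limit of > 20000 nM in this assay, at which 2 of the 2 values shown sit.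

Compound 3, `CSc1nc(N)nc2c1ncn2/C=C1/CC1(CO)CO`, has not yet been measured in this assay. It differs from compound 1 by hydrogen in place of ethyl on a saturated chain carbon bound to a sulfur, a small trimming of the side chain. With both measured compounds at the limit, no step beyond the usual scatter is expected in this assay, and the change from compound 1 to compound 3 is estimated at a number no higher from compound 1 to compound 3 (the limit leaves the size open). Compound 3 is therefore expected to give 20000 nM in this assay, within a range from 10000 nM to 40000 nM, most likely again reported only as a limit.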

Compound 3, half-maximal cytotoxic concentration: > 20000 nM
Compound 3: a limit, no number; the forecaster's own chance of this, stated with the estimate: 85%; the middle value lies on the limit itself.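

No step can be read between compound 1 and compound 3 in this assay: each gives only a limit of the assay, so the change from propylsulfanyl to methylsulfanyl leaves no numbers to compare. The compounds shown leave open the actual half-maximal cytotoxic concentration of each, as all of them stand at the same point: the limit of > 20000 nM in this assay, at which 3 of the 3 values shown sit.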